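The compounds below may be only part of what the source reports. "The series", "measured", "known", "first", "only" and "open" are said of these compounds alone.

Compound 1 `Cc1ccc(C(=O)Nc2cccc(C(F)(F)F)c2)cc1C#Cc1cc(-c2cnn(C)c2)cnc1N` serves as the reference point. In an ADME assay on RBL-2H3 cells (Rattus norvegicus) for cytotoxicity, read by CCK-8 assay, with a stated time of 24 h (a lower number here means that less compound is tolerated, a higher number that more compound is tolerated), compound 1 gives 7 nM, the lowest of the two numbers at hand; its nearest neighbour, compound 2 `Cc1ccc(C(=O)Nc2ccc(OC(F)(F)F)cc2)cc1C#Cc1cc(-c2cnn(C)c2)cnc1N`, gives 41 nM in this assay. Within the data shown here, the single measured step, a 5.9-fold higher number from compound 1 to compound 2 (0.77 log units; beyond the scatter), exchanges the whole aryl group on the amide nitrogen and so bears on compound 3 only loosely. Compound 3 `Cc1ccc(C(=O)Nc2cc(C(F)(F)F)cc(C(F)(F)F)c2)cc1C#Cc1cc(-c2cnn(C)c2)cnc1N` differs from compound 1 by trifluoromethyl in place of hydrogen on an aromatic carbon, meta to a large group, meta to a trifluoromethyl group. Among the measured compounds shown here, no measured pair isolates such an addition, so nothing here shows that a second trifluoromethyl moves the number beyond the scatter. Compound 3 is expected to stay close to its parent: a 1.4-fold lower number from compound 1 to compound 3 (0.15 log units; within the scatter), a step within the usual spread. The estimate for compound 3 in this assay is 5 nM, ranging from 1.5 nM to 20 nM.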

Compound 3, half-maximal cytotoxic concentration: 377 nM
The estimate for compound 3 lay 75-fold (1.88 log units) below the measured number, and the stated range ends below it.
By their numbers in this assay, from the lowest: compound 1; then compound 2; then compound 3.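

In this assay, trifluoromethyl in place of hydrogen on an aromatic carbon, meta to a large group, meta to a trifluoromethyl group, gives a 54-fold higher number from compound 1 to compound 3 (1.73 log units; beyond the scatter), so this position is far from silent: much more compound is tolerated with the group there. Unlike the exchange of the whole aryl group seen earlier, this step isolates a single added group on the otherwise unchanged compound 1. Nothing at hand accounts for the size of this change.

The compounds shown leave open whether the shift belongs to trifluoromethyl itself or would follow any group on this carbon, such as a methyl, a chlorine or an amine. They also leave open whether the same addition would move the number as far on another aryl group.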